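The source may report more compounds than this note shows. Statements on the series, on what has been measured and on what is new or still open speak of the compounds shown alone.

Compound 1 `CCOc1ccc(NS(=O)(=O)c2ccc(C)cc2)c2cn[nH]c12` carries a hydrogen on an aromatic nitrogen of its core, and in a functional assay on A549 cells (Homo sapiens) for cytotoxicity, read by MTT assay, with a stated time of 72 h (a lower number here means a stronger inhibitor, a higher number a weaker inhibitor), compound 1 gives 58500 nM. Compound 2 `C=CCn1ncc2c(NS(=O)(=O)c3ccc(C)cc3)ccc(OCC)c21` differs from it by one change, (allyl in place of hydrogen on an aromatic nitrogen), and in this assay compound 2 gives 100000 nM. The step of a 1.7-fold higher number from compound 1 to compound 2 (0.23 log units; within the scatter) is small. Compound 3 `Cc1ccc(S(=O)(=O)Nc2ccc3c[nH]nc3c2)cc1` has a different core; the difference between the two cores is not broken down here. In this assay compound 3 gives > 100000 nM, which is a limit of the assay rather than a number, as described by the limit of > 100000 nM in this assay, at which 1 of the 3 values shown sits. Compound 4 `C=CCn1cc2ccc(NS(=O)(=O)c3ccc(C)cc3)cc2n1` is related to compound 3 by the same change, (allyl in place of hydrogen on an aromatic nitrogen), placed in exactly the same kind of position as before. Because compound 1 and compound 2 showed only a 1.7-fold higher number from compound 1 to compound 2 (0.23 log units; within the scatter), the step that the limit leaves unreadable from compound 3 to compound 4 is expected to be small as well. Compound 4 is therefore estimated at 150000 nM in this assay, within a range from 70000 nM to 320000 nM, and most likely the assay will again report only a limit.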

Compound 4, half-maximal inhibitory concentration: 11900 nM
Compound 4: middle estimate off by 13-fold (1.10 log units), on the high side, outside the stated range (below it).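

Set on an aromatic nitrogen, allyl in place of hydrogen gives an at least 8.4-fold lower number from compound 3 to compound 4 (0.92 log units; beyond the scatter), so in this assay the step on one core does not predict the step on the other: the same change on two cores in this assay, a 1.7-fold higher number (0.23 log units; within the scatter) from compound 1 to compound 2 and an at least 8.4-fold lower number (0.92 log units; beyond the scatter) from compound 3 to compound 4, at least 14-fold (1.15 log units) apart, beyond the scatter of two such steps

Compound 3 gives > 100000 nM, which is a limit of the assay and not a number, so the step on this core is known only as a minimum: the limit of > 100000 nM in this assay, at which 1 of the 4 values shown sits.

These two pairs show that the same change can behave differently across cores in this series, but they do not show which feature of the cores matters, why the steps differ, or what the change would do on a third core.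

As far as these compounds go, whether the lower number of compound 4 is particular to allyl stays open, and a methyl, a longer chain or a chain ending in an amine on the same nitrogen would test this. From the compounds shown here alone, whether the step on this core also holds in other cell lines stays open too.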